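Swapping a Chain Methyl for Pyrrolidinyl in Quinazoline Amines

The source may report more compounds than this note shows. Statements on the series, on what has been measured and on what is new or still open speak of the compounds shown alone.

Measured so far:
compound 1, `CCCCNc1nc(NCc2ccco2)c2ccccc2n1`: 89.9%
compound 2, `Cc1cccc(N2CCN(CCCNc3nc(NCc4ccco4)c4ccccc4n3)CC2)c1C`: 91.5%
compound 3, `CCCCNc1nc(NCc2ccco2)c2cccc(F)c2n1`: "not determined" (no result reported)

Compound 1 carries a plain four-carbon chain on one amine of the shared core. In a functional assay on DU-145 cells (Homo sapiens) for cytotoxicity, read by MTT assay, with a stated time of 2 days, tested at 10 uM (on this read-out lower numbers stand for less inhibition and higher numbers for more inhibition at the one concentration tested (going by the name of the read-out)), compound 1 gives 89.9%. Compound 2, which carries a longer chain ending in a ring-bearing amine, gives 91.5% in this assay. The two numbers lie within the usual scatter of each other, so neither can be called stronger. A ring-fluorinated relative of compound 1 is compound 3, for which this assay reports "not determined" (no result reported).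

Compound 4, `c1coc(CNc2nc(NCCCN3CCCC3)nc3ccccc23)c1`, is not yet measured. It differs from compound 1 in one place: pyrrolidin-1-yl in place of methyl on a saturated chain carbon, three bonds along the chain from a nitrogen on an aromatic ring. Compound 2 shows that adding an amine-bearing ring on the chain leaves the read-out close to that of compound 1, so the step from compound 1 to compound 4 is expected to stay within the scatter, a number 0.1 percentage points higher from compound 1 to compound 4 (within the scatter). Compound 4 is therefore estimated at 90%, from 78% to 97%.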

Compound 4, a percentage reported as inhibition, at one concentration (the size of the read-out at that concentration, not a potency): 40.1%
The estimate for compound 4 lay 49.9 percentage points above the measured number, outside the stated range (below it).
By their numbers in this assay, from the lowest: compound 4; then compounds 1 and 2 (each within the scatter of the next).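

In this assay, putting pyrrolidin-1-yl in place of methyl on a saturated chain carbon, three bonds along the chain from a nitrogen on an aromatic ring, gives a number 49.8 percentage points lower from compound 1 to compound 4 (beyond the scatter). This shows that the read-out is sensitive to what sits at this place on the chain, and that an amine-bearing ring there does not always leave it unchanged: compound 2 gives 91.5%, while compound 4 gives 40.1%. Nothing available explains this drop.

As far as these compounds go, it remains open whether the drop belongs to the pyrrolidin-1-yl ring itself or to any amine at this place, which a dimethylamino group or a piperidine ring on the same chain could help to separate. The compounds shown also leave open how pyrrolidin-1-yl would read on a shorter or a longer chain.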